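Aryl replacement on the shared core: cytotoxicity working notes

This account rests on a few compounds, and the source may have more. Where it says the series, first, only, none or still open, it means among the compounds named here.

Measured compounds and their values:
compound 1 `CC(C)N(Cc1cccc(OCCCCCC(=O)O)c1)C(=O)c1ccc(-c2cccc3ccccc23)cc1`: in an ADME assay on HepG2 cells (Homo sapiens) for cytotoxicity, read by CellTiter-Glo and resazurin assay, with a stated time of 72 h (on this read-out higher numbers stand for an effect only at larger amounts of compound and lower numbers for an effect already at smaller amounts), compound 1 gives > 26000 nM, which is a limit of the assay.
compound 2 `CC(C)N(Cc1cccc(OCCCCCC(=O)O)c1)C(=O)c1ccc(-c2ccncc2)cc1`: in this assay compound 2 gives > 26000 nM, a limit.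
compound 3 `CC(C)Oc1cccc(-c2ccc(C(=O)N(Cc3cccc(OCCCCCC(=O)O)c3)C(C)C)cc2)c1`: in this assay compound 3 gives > 26000 nM, a limit.

Compound 2 stands only at a limit in this assay, and the whole set sits there as well (the limit of > 26000 nM in this assay, at which 3 of the 3 values shown sit). The steps a step that the two limits leave unreadable from compound 1 to compound 2, a step that the two limits leave unreadable from compound 1 to compound 3 and a step that the two limits leave unreadable from compound 2 to compound 3 cannot be read in size for that reason. Compound 4 `CC(C)N(Cc1cccc(OCCCCCC(=O)O)c1)C(=O)c1ccc(-c2cccc(Br)c2)cc1` differs from compound 2 as follows: 3-bromophenyl in place of pyridin-4-yl on an aromatic carbon. Going by the values given here, no measured step gives a readable size for a change of this kind. The step expected here is a step that the limit leaves unreadable from compound 2 to compound 4, with no direction readable. Compound 4 is expected to remain at the same limit in this assay. The estimate for compound 4 is 40000 nM, with a range of 20000 nM to 120000 nM, most likely reported only as a limit.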

Compound 4, half-maximal effective concentration: > 26000 nM
Compound 4 ended at the assay's limit (the forecaster's own chance of this, stated with the estimate: 85%); the middle value does not contradict the limit.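

Compound 4 gives no readable step from compound 1, compound 2 or compound 3, since all four results are limits and not numbers: the limit of > 26000 nM in this assay, at which 4 of the 4 values shown sit.

Going by these compounds, whether any aryl group on the shared core brings cytotoxicity into a readable range stays open.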